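The compounds below may be only part of what the source reports. "The series", "measured", "known", "first", "only" and "open" are said of these compounds alone.

Two compounds measured in an assay on cell membranes for binding affinity to metabotropic glutamate receptor 5 (Rattus norvegicus) (on this read-out higher numbers stand for weaker inhibition and lower numbers for stronger inhibition), frame this step. Compound 1 `COc1cc(C#N)cc(-n2nnc(-c3ccccn3)n2)c1` gives 6 nM, and compound 2 `N#Cc1cc(N)cc(-n2nnc(-c3ccccn3)n2)c1` gives 95 nM. Within the data shown here, the single structural step between them, amino in place of methoxy on an aromatic carbon, produced a 16-fold higher number from compound 1 to compound 2 (1.20 log units; beyond the scatter). Among the measured compounds shown here, compound 2 therefore stands at the highest of the two numbers seen so far, with compound 1 as its only neighbour at a clearly lower number.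

Compound 3 `N#Cc1cc(OCc2ccccc2)cc(-n2nnc(-c3ccccn3)n2)c1` has not been measured. The change that leads to it is benzyloxy in place of amino on an aromatic carbon. For the measured compounds named here, the only measured step that bears on this change is the one from compound 1 to compound 2, in which the ether oxygen was replaced by an amino group and the number rose strongly. Going by the values given here, compound 3 restores an ether oxygen at the same position, now carrying a benzyl group rather than a methyl, so the expectation is a step back toward the lower number of compound 1, although the added ring gives no measured precedent. On that basis the expected step is a 6.3-fold lower number from compound 2 to compound 3 (0.80 log units; beyond the scatter), and compound 3 is estimated at 15 nM, with a likely range from 3 nM to 80 nM.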

Compound 3, inhibition constant: > 600 nM
Compound 3 gave a limit, no number; the forecaster's own chance of this, stated with the estimate: 2%; middle value at least 40-fold (1.60 log units) away from the limit.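

In this assay, compound 3 gives a limit of the assay rather than a number: the limit of > 600 nM in this assay, at which 1 of the 3 values shown sits. Putting an ether oxygen back at this position did not return the low number of compound 1, since the change from amino to benzyloxy brought an at least 6.3-fold higher number from compound 2 to compound 3 (0.80 log units; beyond the scatter), so the oxygen alone does not decide the outcome here. The closer comparison keeps the oxygen and adds only a phenyl to the saturated carbon bound to it, which brought an at least 100-fold higher number from compound 1 to compound 3 (2.00 log units; beyond the scatter), and this shows that what is attached to that oxygen matters a great deal at this position, which the earlier pair of methoxy and amino could not reveal.

The compounds shown leave open where between methoxy and benzyloxy the number begins to climb, a question that an ethoxy group or a short propoxy chain would address. They also leave open whether a benzylamino group, with nitrogen in place of the oxygen, would behave like benzyloxy, and the limit leaves the true size of both new steps unknown.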